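The source may hold more compounds than are shown below. What is called first, only, known or untested is meant among the compounds shown, and "the series" means these compounds.

Measured compounds in a functional assay on Jurkat cells (Homo sapiens) for activation, with a stated time of 24 h; a lower number here means that less compound is needed, a higher number that more compound is needed for the effect:
- compound 1, `Oc1cc(I)ccc1CNc1ccc(C2CCCCC2)cc1`: "not active" (no number reported)
- compound 2, `Cc1cccc(CNc2ccc(C3CCCCC3)cc2)c1O`: "not active" (no number reported)
- compound 3, `Cc1ccc(-c2ccc(NCc3ccccc3O)cc2)cc1`: 3790 nM

For the measured compounds named here, compound 3 is the only member of the set with a numerical result in this assay; compound 1 and compound 2 carry no number at all, only the report that no activity was seen. Compound 3 therefore stands alone as the reference point, and nothing can be said about its rank against the other two beyond that it gave a measurable half-maximal effective concentration while they did not.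

The next compound, compound 4, `Oc1ccc(-c2ccc(NCc3ccccc3O)cc2)cc1`, keeps the whole of compound 3 apart from one position. The difference is hydroxy in place of methyl on an aromatic carbon. Put more fully, the 4-methylphenyl of compound 3 becomes a 4-hydroxyphenyl in compound 4.

Going by the values given here, no pair of measured compounds differing in one place exists here, so the size of this step cannot be read from the set. The expectation is a step of a 1.1-fold higher number from compound 3 to compound 4 (0.02 log units; within the scatter) in this assay, that is, no change clearly beyond the scatter in either direction. For compound 4 the estimated half-maximal effective concentration is 4000 nM, with a range from 1300 nM to 12000 nM.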

Compound 4, half-maximal effective concentration: "not active" (no number reported)
Compound 4 has no reported number here, and the estimate cannot be compared.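

For the compounds shown here, compound 4 carries no number in this assay, so no step from compound 3 can be read. No available evidence bears on this result. The compounds shown leave open how the 4-hydroxyphenyl and 4-methylphenyl compare numerically, and which single changes separate measurable from inactive compounds.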